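The source may report more compounds than this note shows. Statements on the series, on what has been measured and on what is new or still open speak of the compounds shown alone.

Working notes on the series. Within the data shown here, compound 1 `CC(C)[C@@H]1CC[C@@H](C)C[C@@]12N(C)C(=O)[C@@H]1[C@H]3C(=O)N(C)C(=O)[C@H]3ON12` stands highest of the two numbers measured so far: in a functional assay, with a stated time of 20 min, tested at 1 mg/mL (a lower number here means a weaker effect, a higher number a stronger effect of the compound at the concentration tested), compound 1 gives 43.1%. Among the measured compounds shown here, compound 2 `CC(C)[C@@H]1CC[C@@H](C)C[C@@]12N(C)C(=O)[C@@H]1[C@H]3C(=O)N(c4ccc(Cl)cc4)C(=O)[C@H]3ON12` gives 31.7% in this assay, and the single step measured so far, a number 11.4 percentage points lower from compound 1 to compound 2 (beyond the scatter), runs in one direction only and is modest. The unmeasured compound 3 `CC(C)[C@@H]1CC[C@@H](C)C[C@@]12N(C)C(=O)[C@@H]1[C@H]3C(=O)N(c4ccc5ccccc5c4)C(=O)[C@H]3ON12` differs from compound 1 as follows: naphthalen-2-yl in place of methyl on an amide-type nitrogen in a ring. For the measured compounds named here, the only step that bears on this is the one in which a 4-chlorophenyl replaced methyl on the same amide-type nitrogen in a ring, a number 11.4 percentage points lower from compound 1 to compound 2 (beyond the scatter); since naphthalen-2-yl also brings six-membered aromatic rings of carbon only onto that nitrogen, a step of similar size and direction is expected, a number 14.1 percentage points lower from compound 1 to compound 3 (beyond the scatter). Compound 3 is therefore estimated to give 29% in this assay, within a range from 16% to 42%.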

Compound 3, a percentage reported as activity, at one concentration (the size of the read-out at that concentration, not a potency): 27.6%
The estimate for compound 3 lay 1.4 percentage points above the measured number, within the range that was stated.
By their numbers in this assay, from the lowest: compounds 3 and 2 (each within the scatter of the next); then compound 1.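

On the amide-type nitrogen in a ring, a second group with six-membered aromatic rings of carbon only also gives a lower number in this assay: a number 15.5 percentage points lower from compound 1 to compound 3 (beyond the scatter). Compound 2 and compound 3 cannot be told apart at this position, a number 4.1 percentage points lower from compound 2 to compound 3 (within the scatter), so 4-chlorophenyl and naphthalen-2-yl read alike here, and the two rings of naphthalen-2-yl carry no visible difference from the single ring of 4-chlorophenyl. No independent measurement bears on the reason for these steps.

Open, on these data alone, is whether the lower numbers go with aromatic rings on this nitrogen or with any group other than methyl, a question that a cyclohexyl group or a longer alkyl chain there could separate. Also open, as far as these compounds go, is how a group carrying an amine or a carboxylic acid at this position would compare with compound 1.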